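The compounds below may be only part of what the source reports. "The series", "measured", "known", "first", "only" and "open" are said of these compounds alone.

Three closely related compounds have been tested in a functional assay on LM7 cells (Homo sapiens) for cytotoxicity, read by MTT assay, with a stated time of 72 h; a higher number here means a weaker inhibitor, a lower number a stronger inhibitor. Compound 1 `O=c1cc(CSc2nc3ccccc3s2)oc2ccccc12` is the simplest of them. In this assay compound 1 gives > 25000 nM, which is a limit of the assay and not a number. Compound 3 `Cc1ccc2oc(CSc3nc4ccccc4s3)cc(=O)c2c1` differs from compound 1 by a single change, (methyl in place of hydrogen on an aromatic carbon). In this assay compound 3 gives > 25000 nM, again a limit. The step that the two limits leave unreadable from compound 1 to compound 3 therefore cannot be sized. Compound 2 `Cc1nnc(SCc2cc(=O)c3ccccc3o2)s1` carries a different core; how the two cores differ is not broken down here. In this assay compound 2 gives > 25000 nM, once more a limit. All three measured values sit at the limit of > 25000 nM in this assay, at which 3 of the 3 values shown sit. Compound 4 `Cc1ccc2oc(CSc3nnc(C)s3)cc(=O)c2c1` has not yet been measured; it differs from compound 2 by methyl in place of hydrogen on an aromatic carbon, the same change made from compound 1 to compound 3, at the same place. Because compound 2 gives > 25000 nM, compound 4 is expected to come out near 30000 nM in this assay, most likely again as a limit. The expected step that the limit leaves unreadable from compound 2 to compound 4 is an estimate only. It rests on nothing more than the step that the two limits leave unreadable from compound 1 to compound 3, which cannot be sized.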

Compound 4, half-maximal inhibitory concentration: > 25000 nM
Compound 4: no number, only a limit; the forecaster's own chance of this, stated with the estimate: 85%; the middle value lies beyond the limit too.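

No step can be read from compound 1 to compound 3 or from compound 2 to compound 4, as each compound gives only a limit and not a number: the limit of > 25000 nM in this assay, at which 4 of the 4 values shown sit.

The compounds shown leave open whether methyl in place of hydrogen changes activity at all, and which structure would give a measurable value in this assay.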